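The source may hold more compounds than are shown below. What is called first, only, known or untested is meant among the compounds shown, and "the series" means these compounds.

Of the compounds shown here, two sharing a common core have been measured in a functional assay on OVCAR-8 cells (Homo sapiens) for inhibition, read by sulforhodamine B assay, with a stated time of 48 h; on this read-out lower numbers stand for stronger inhibition of growth and higher numbers for weaker inhibition of growth. Compound 1, `CCOC(=O)[C@H](CCC(=O)O)NC(=O)c1ccc(Sc2nc3cc(N)cc(N)c3nc2-c2ccccc2)cc1`, gives 12000 nM in this assay. Compound 2, `Nc1cc(N)c2nc(-c3ccccc3)c(Sc3ccc(F)cc3)nc2c1`, gives 16600 nM in this assay. The two numbers lie within the usual scatter of repeated measurements of each other, so nothing separates compound 1 from compound 2 on these data, and compound 2 cannot be called weaker or stronger than its partner.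

Compound 3, `COc1ccc(Sc2nc3cc(N)cc(N)c3nc2-c2ccccc2)cc1`, has not yet been measured in this assay. It differs from compound 2 in a single place: methoxy in place of fluoro on an aromatic carbon. The change sits on an aromatic carbon of a six-membered aromatic ring of carbon only, para to a large group, and the rest of the molecule is untouched.

Among the measured compounds shown here, no pair of measured compounds shows what this kind of exchange does here, so there is no step to lean on. The expectation is a step from compound 2 to compound 3 of about a 1.1-fold lower number from compound 2 to compound 3 (0.04 log units; within the scatter), that is, nothing beyond the scatter in either direction. Compound 3 is therefore estimated at 15000 nM in this assay, with a likely range from 6000 nM to 40000 nM.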

Compound 3, concentration for 50% growth inhibition: < 100000 nM
Compound 3 gave a limit, no number (the forecaster's own chance of this, stated with the estimate: 10%); the middle value is on the limit's open side.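

In this assay compound 3 gives < 100000 nM, which is a limit of the assay and not a number. No step can be read from compound 2 to compound 3. The compounds shown leave open whether methoxy in place of fluoro on this aromatic carbon changes growth inhibition at all, and in which direction.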